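The source may hold more compounds than are shown below. What is called first, only, known or untested is meant among the compounds shown, and "the series" means these compounds.

Compounds measured so far:
- compound 1, `CCC(=O)N(C)c1ccc2[nH]c(-c3n[nH]c4ccccc34)cc2n1`: 33500 nM
- compound 2, `CN(C(=O)c1ccc(Br)cc1)c1ccc2[nH]c(-c3n[nH]c4ccccc34)cc2n1`: 3460 nM
- compound 3, `CN(c1ccc2[nH]c(-c3n[nH]c4ccccc34)cc2n1)S(=O)(=O)c1ccc(Cl)cc1`: 12700 nM

All three share one core and differ only in the group carried on the methylated nitrogen. In a functional assay on SMMC-7721 cells (Homo sapiens) for antiproliferative activity, read by MTT assay, with a stated time of 72 h (a lower number here means a stronger inhibitor, a higher number a weaker inhibitor), compound 1 gives the highest of the three numbers, making it the weakest inhibitor shown; the nearest is compound 3 and the furthest is compound 2, as the steps of a 2.6-fold lower number from compound 1 to compound 3 (0.42 log units; beyond the scatter) and a 9.7-fold lower number from compound 1 to compound 2 (0.99 log units; beyond the scatter) show. Between the two larger groups, a 3.7-fold higher number from compound 2 to compound 3 (0.56 log units; beyond the scatter) separates them.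

Compound 4, `CN(C(=O)Nc1ccccc1)c1ccc2[nH]c(-c3n[nH]c4ccccc34)cc2n1`, has not yet been measured. It differs from compound 1 as follows: anilino in place of ethyl on a carbonyl carbon. Among the measured compounds shown here, the closest precedent is the step from compound 1 to compound 2, where an aromatic ring also replaced the ethyl on the carbonyl carbon and the number fell modestly. For the measured compounds named here, the anilino group brings a ring but also an added hydrogen-bond donor, for which no measured pair gives guidance, so the expectation is a smaller gain than compound 2 showed.

Compound 4 is therefore expected to give 10000 nM in this assay, within a range of 3000 nM to 30000 nM, a step of a 3.4-fold lower number from compound 1 to compound 4 (0.53 log units; beyond the scatter) that is expected to lie beyond the scatter.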

Compound 4, half-maximal inhibitory concentration: 280 nM
The estimate for compound 4 lay 36-fold (1.55 log units) above the measured number; the whole stated range lies above it.
By their numbers in this assay, from the lowest: compound 4; then compound 2; then compound 3; then compound 1.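

In this assay, among the compounds shown here, the carbonyl carbon on the methylated nitrogen proves far more responsive than the earlier compounds suggested: anilino in place of ethyl gives a 120-fold lower number from compound 1 to compound 4 (2.08 log units; beyond the scatter), well beyond a 9.7-fold lower number from compound 1 to compound 2 (0.99 log units; beyond the scatter) seen with 4-bromophenyl. Gaining an aromatic ring on that carbon therefore does not by itself account for the result, as anilino in place of 4-bromophenyl still gives a 12-fold lower number from compound 2 to compound 4 (1.09 log units; beyond the scatter), and phenylcarbamoyl in place of (4-chlorophenyl)sulfonyl on the nitrogen gives a 45-fold lower number from compound 3 to compound 4 (1.66 log units; beyond the scatter). No independent measurement here bears on why this change lowers the number so much.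

Compound 2 and compound 4 differ in both the bromine and the anilino nitrogen, so the compounds shown cannot separate the contributions of these two features, or show whether the amide hydrogen of the anilino group matters. A plain phenyl on the carbonyl carbon, a 4-bromoanilino group and an anilino group with a methyl on its nitrogen would each address part of that question.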